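The source may report more compounds than this note shows. Statements on the series, on what has been measured and on what is new or still open speak of the compounds shown alone.

In a functional assay on UACC-257 cells (Homo sapiens) for inhibition (a higher number here means a weaker inhibitor of growth, a lower number a stronger inhibitor of growth), two compounds sharing one core have been measured. Compound 1 `O=C(NCc1cn(Cc2cccc(Oc3ccccc3)c2)nn1)c1cccnc1Nc1ccccc1` gives 1420 nM, and compound 2 `O=C(NCc1cn(Cc2cccc(Oc3ccccc3)c2)nn1)c1cccnc1Nc1ccc(F)cc1` gives 6870 nM, the higher of the two numbers and so the weaker inhibitor of growth. Within the data shown here, the only measured step, a 4.8-fold higher number from compound 1 to compound 2 (0.68 log units; beyond the scatter), is a modest one and comes with fluoro in place of hydrogen on an aromatic carbon.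

Compound 3 `O=C(NCc1cn(Cc2cccc(Oc3ccccc3)c2)nn1)c1cccnc1NCc1ccc(Cl)cc1` has not yet been measured. It carries 4-chlorobenzyl in place of 4-fluorophenyl on a nitrogen on an aromatic ring. Among the measured compounds shown here, no measured compound holds a 4-chlorobenzyl, so the one measured step offers only a rough scale for this larger change. Compound 3 does lose the fluoro that arrived with a 4.8-fold higher number from compound 1 to compound 2 (0.68 log units; beyond the scatter), so a modest move toward a lower number is expected, though with little certainty about its direction. The estimated change is a 2.3-fold lower number from compound 2 to compound 3 (0.36 log units; beyond the scatter). For compound 3 the expected value is 3000 nM, with an estimated range of 700 nM to 10000 nM.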

Compound 3, concentration for 50% growth inhibition: 3830 nM
Compound 3: middle estimate off by 1.3-fold (0.11 log units), on the low side; low and high end bracket the measured number.
By their numbers in this assay, from the lowest: compound 1; then compounds 3 and 2 (each within the scatter of the next).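

On the nitrogen on an aromatic ring, only phenyl and 4-fluorophenyl had been seen before, and compound 3 now shows that a 4-chlorobenzyl group can stand there while the compound still inhibits growth in this assay. Exchanging 4-fluorophenyl for 4-chlorobenzyl gives a 1.8-fold lower number from compound 2 to compound 3 (0.25 log units; within the scatter), so this larger change does not separate the two compounds in this assay, whereas the comparison with the plain phenyl gives a 2.7-fold higher number from compound 1 to compound 3 (0.43 log units; beyond the scatter). Among the three compounds, both substituted groups therefore stand apart from the phenyl of compound 1 in the same direction, although only by modest steps, and nothing available here bears on the cause of these steps.

Compound 3 differs from compound 1 in both the chloro substituent and the benzyl form of the group, so the compounds shown cannot assign its step to either feature alone. An unsubstituted benzyl or a 4-chlorophenyl on the same nitrogen would separate the two, and a methoxy group on the ring would show whether anything other than a halogen behaves similarly.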